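A Nitro Group Added to Two Related Compounds

The source may hold more compounds than are shown below. What is called first, only, known or untested is meant among the compounds shown, and "the series" means these compounds.

Compound 1 `CCS(=O)(=O)Nc1ccc(NC(=O)c2ccc(Cl)cc2)cc1C` and compound 2 `CCS(=O)(=O)Nc1ccc(NC(=O)c2ccc(Cl)c([N+](=O)[O-])c2)cc1C` share one core and differ by a single change, (nitro in place of hydrogen on an aromatic carbon). In an ADME assay on HEK293 cells (Homo sapiens) for cytotoxicity, read by MTT assay, with a stated time of 48 h (on this read-out lower numbers stand for stronger inhibition and higher numbers for weaker inhibition), compound 1 gives 125000 nM. In this assay compound 2 gives 144000 nM. That step is a 1.2-fold higher number from compound 1 to compound 2 (0.06 log units; within the scatter), so the nitro group left the read-out essentially unchanged. Compound 3 `COc1cc(NC(=O)c2ccc(Cl)cc2)ccc1NS(C)(=O)=O` is built on a second core; the difference between the two cores is not broken down here. In this assay compound 3 reaches only a limit, > 250000 nM, and so do a share of the values seen, (the limit of > 250000 nM in this assay, at which 1 of the 3 values shown sits). Compound 4 `COc1cc(NC(=O)c2ccc(Cl)c([N+](=O)[O-])c2)ccc1NS(C)(=O)=O` applies the same change to compound 3, (nitro in place of hydrogen on an aromatic carbon). A step of about a number no higher from compound 3 to compound 4 (the limit leaves the size open) is expected, because the earlier step of a 1.2-fold higher number from compound 1 to compound 2 (0.06 log units; within the scatter) was within the scatter. Compound 4 is therefore estimated at 250000 nM, most likely again reported only as a limit.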

Compound 4, half-maximal inhibitory concentration: 164000 nM
Compound 4: middle estimate off by 1.5-fold (0.18 log units), on the high side, within the range that was stated.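

Adding the nitro group to the second core gives an at least 1.5-fold lower number from compound 3 to compound 4 (0.18 log units; that floor lies within the scatter). Set side by side, the two cores compare as follows: the same change on two cores in this assay, a 1.2-fold higher number (0.06 log units; within the scatter) from compound 1 to compound 2 and an at least 1.5-fold lower number (0.18 log units; that floor lies within the scatter) from compound 3 to compound 4; the limit leaves it open whether they differ The pair therefore does not show that the change carries over in the same way from one core to the other, nor does it show that the change behaves differently on the second core.

The compounds shown leave open what an amine or a carboxylic acid in the place of the nitro group would give in this assay. They also leave open how the same change would read on any core beyond these two.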